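Oxime side chain: free acid against acetyl

A few compounds are considered here, and "the series" means these few. Any claim that something is new, unique, unknown or untested is made for them only; others in the source may bear on it.

Working notes on the series built on the core of compound 3 `COc1ccc(/C(=N/OCC(=O)O)c2cccc3ccccc23)c(OC)c1OC`. In a functional assay on HCT-116 cells (Homo sapiens) for inhibition, read by sulforhodamine B assay, with a stated time of 48 h (a higher number here means a weaker inhibitor, a lower number a stronger inhibitor), compound 3 gives 4980 nM, the lowest of the two numbers recorded; the nearest is compound 1 `CCOC(=O)CCO/N=C(/c1ccc(OC)c(OC)c1OC)c1cccc2ccccc12`, which in this assay gives 10000 nM. Compound 2 `CCOC(=O)/C=C/CO/N=C(/c1ccc(OC)c(OC)c1OC)c1cccc2ccccc12` reaches only a limit of this assay, > 20000 nM. That it is a limit is recorded separately (the limit of > 20000 nM in this assay, at which 1 of the 3 values shown sits).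

Three steps are measured on the side chain hanging from the oxime oxygen. Exchanging the ethyl ester arm for the free acid gives a 2.0-fold lower number from compound 1 to compound 3 (0.30 log units; within the scatter). Lengthening the ester arm into the unsaturated one gives an at least 2.0-fold higher number from compound 1 to compound 2 (0.30 log units; that floor lies within the scatter), and from that unsaturated ester to the free acid the step is an at least 4.0-fold lower number from compound 2 to compound 3 (0.60 log units; beyond the scatter).

Compound 4 `COc1ccc(/C(=N/OC(C)=O)c2cccc3ccccc23)c(OC)c1OC` carries a different change: acetyl in place of carboxymethyl on an oxygen. Within the data shown here, none of the measured steps touch an acetyl; the only bearing they have is that swapping the acid for an ester arm moved this assay little, while the longer unsaturated arm ran to the limit. A small step, in either direction, is therefore expected for compound 4, a 1.4-fold higher number from compound 3 to compound 4 (0.15 log units; within the scatter). The estimate for compound 4 in this assay is 7000 nM, within 2500 nM to 20000 nM.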

Compound 4, half-maximal inhibitory concentration: 4980 nM
Estimate against measurement, compound 4: 1.4-fold (0.15 log units) above, within the range that was stated.
By their numbers in this assay, from the lowest: compounds 3, 4 and 1 (each within the scatter of the next). At a limit, above all of these: compound 2.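

In this assay, acetyl in place of carboxymethyl on an oxygen gives no change at the digits printed from compound 3 to compound 4 (within the scatter), so the hydrogen-bond donor of the free acid is not needed to hold this level: the acetyl carries none, and it is also the smaller of the two groups by heavy atoms. The ethyl ester arm gives no separable reading against the acetyl either, with a 2.0-fold lower number from compound 1 to compound 4 (0.30 log units; within the scatter), so compounds 1, 3 and 4 cannot be put in any order on this side chain, and neither the free acid nor the acetyl marks out a preferred end to it. Only the unsaturated ester arm stands apart from the acetyl, with an at least 4.0-fold lower number from compound 2 to compound 4 (0.60 log units; beyond the scatter), and that step rests on a limit of the assay, not a number: the limit of > 20000 nM in this assay, at which 1 of the 4 values shown sits.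

As far as these compounds go, what remains open is whether any carbonyl is needed on this oxygen, which a plain methyl or a benzyl group there would test. An amine such as 2-aminoethyl, or a longer saturated chain ending in a carboxylic acid, would show whether this side chain can move the number beyond the scatter in the favourable direction at all.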